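The compounds below may be only part of what the source reports. "The series", "measured", "known", "first", "only" and "open" are said of these compounds alone.

Measured compounds in a functional assay on HepG2 cells (Homo sapiens) for inhibition, read by MTT assay, with a stated time of 72 h; on this read-out higher numbers stand for weaker inhibition and lower numbers for stronger inhibition:
compound 1 `CN(C(=O)NC(=O)c1ccc(F)c(F)c1)c1nc(C(F)(F)F)c(C(=O)N/N=C/c2cccc(C(F)(F)F)c2)s1` gives 5.6 ug/mL;
compound 2 `CN(C(=O)NC(=O)c1ccc([N+](=O)[O-])cc1)c1nc(C(F)(F)F)c(C(=O)N/N=C/c2cccc(C(F)(F)F)c2)s1` gives 4.73 ug/mL;
compound 3 `CN(C(=O)NC(=O)c1ccccc1F)c1nc(C(F)(F)F)c(C(=O)N/N=C/c2cccc(C(F)(F)F)c2)s1` gives 20.3 ug/mL.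

Compound 3 stands highest of the three numbers, that is, weakest on this read-out, and its separation from the other two is beyond the scatter. Compound 4 `CN(C(=O)NC(=O)c1cccc(C(F)(F)F)c1)c1nc(C(F)(F)F)c(C(=O)N/N=C/c2cccc(C(F)(F)F)c2)s1` differs from compound 3 in one place: 3-(trifluoromethyl)phenyl in place of 2-fluorophenyl on a carbonyl carbon. Two of the three measured steps bear on this kind of change, since each of them swaps one aryl group for another on the same carbonyl carbon. From compound 1 to compound 3 the number rose: a 3.6-fold higher number from compound 1 to compound 3 (0.56 log units; beyond the scatter). From compound 2 to compound 3 the number rose by a similar amount: a 4.3-fold higher number from compound 2 to compound 3 (0.63 log units; beyond the scatter). The third step, a 1.2-fold lower number from compound 1 to compound 2 (0.07 log units; within the scatter), lies within the scatter, so two rather different aryl groups gave about the same number. Among the measured compounds shown here, no measured step involves a 3-(trifluoromethyl)phenyl group on this carbonyl, so its effect is not known from these data. Because compound 3 gives 20.3 ug/mL and sits at the top of the range, an estimate of a modest fall toward the other two values seems reasonable, though a step within the scatter cannot be excluded. Compound 4 is therefore estimated to give 9 ug/mL, with a range of 3.5 ug/mL to 24 ug/mL. This expected step is a 2.3-fold lower number from compound 3 to compound 4 (0.35 log units; beyond the scatter).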

Compound 4, half-maximal inhibitory concentration: 5.79 ug/mL
Compound 4: middle estimate off by 1.6-fold (0.19 log units), on the high side; measured number inside the range.
By their numbers in this assay, from the lowest: compounds 2, 1 and 4 (each within the scatter of the next); then compound 3.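

In this assay, putting 3-(trifluoromethyl)phenyl in place of 2-fluorophenyl on the carbonyl carbon gives a 3.5-fold lower number from compound 3 to compound 4 (0.54 log units; beyond the scatter), which shows that a group with more heavy atoms than 2-fluorophenyl is accepted here without any loss on this read-out. The new group also matches the two earlier aryl groups, with a 1.2-fold higher number from compound 2 to compound 4 (0.09 log units; within the scatter) from the 4-nitrophenyl group and a 1.0-fold higher number from compound 1 to compound 4 (0.01 log units; within the scatter) from the 3,4-difluorophenyl group, so three different aryl groups now share one level and 2-fluorophenyl alone stands apart among the four shown. No measurement offered here explains why the 2-fluorophenyl compound differs from the other three.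

The compounds shown leave open whether the weaker reading of compound 3 belongs to 2-fluorophenyl specifically or would also appear with a 2-chlorophenyl or 2-methylphenyl group on the same carbonyl carbon. They also leave open whether an aryl group is needed here at all, since an unsubstituted phenyl, a pyridine ring, a cyclohexyl group or a simple methyl group could read quite differently on this carbonyl carbon.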